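A few compounds are considered here, and "the series" means these few. Any claim that something is new, unique, unknown or untested is made for them only; others in the source may bear on it.

Measured compounds in an ADME assay on Caco-2 cells (Homo sapiens) for permeability, in the apical to basolateral direction; on this read-out higher numbers stand for higher permeability and lower numbers for lower permeability:
- compound 1 `O=c1ncn(Cc2c(F)cc(F)cc2F)c2ccc(Oc3ccccc3C(F)(F)F)cc12`: 9.2 10^-6 cm/s
- compound 2 `O=C(Nc1ccccn1)c1cccc(Oc2ccc3c(c2)c(=O)ncn3Cc2c(F)cc(F)cc2F)c1C(F)(F)F`: 1.2 10^-6 cm/s
- compound 3 `O=c1ncn(Cc2c(F)cc(F)cc2F)c2ccc(Oc3cccc(-c4ccc5[nH]cnc5c4)c3C(F)(F)F)cc12`: 0.4 10^-6 cm/s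

Compound 3 stands lowest of the three in this assay; the nearest is compound 2 (a 3.0-fold lower number from compound 2 to compound 3 (0.48 log units; beyond the scatter)), the furthest compound 1 (a 23-fold lower number from compound 1 to compound 3 (1.36 log units; beyond the scatter)). Compound 4 `Nc1ccc(-c2cccc(Oc3ccc4c(c3)c(=O)ncn4Cc3c(F)cc(F)cc3F)c2C(F)(F)F)cn1` differs from compound 3 by 6-aminopyridin-3-yl in place of 1H-benzimidazol-5-yl on an aromatic carbon. Among the measured compounds shown here, the steps that bear on it are the two additions at this carbon, a 7.7-fold lower number from compound 1 to compound 2 (0.88 log units; beyond the scatter) and a 23-fold lower number from compound 1 to compound 3 (1.36 log units; beyond the scatter), and the swap between them, a 3.0-fold lower number from compound 2 to compound 3 (0.48 log units; beyond the scatter): each added group lowered the number, the benzimidazole most. Compound 4 keeps a donor-bearing aromatic group here but a smaller one, so a step up, modest at most, is expected: a 1.8-fold higher number from compound 3 to compound 4 (0.24 log units; within the scatter). Compound 4 is therefore estimated at 0.7 10^-6 cm/s, within 0.25 10^-6 cm/s to 2 10^-6 cm/s.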

Compound 4, apparent permeability: 4.1 10^-6 cm/s
The estimate for compound 4 lay 5.9-fold (0.77 log units) below the measured number; measured number outside the range, above it.
By their numbers in this assay, from the lowest: compound 3; then compound 2; then compound 4; then compound 1.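

In this assay, the group at this carbon moves the number widely, even between groups with the same hydrogen-bond donor count: a 10-fold higher number from compound 3 to compound 4 (1.01 log units; beyond the scatter), alongside a 3.4-fold higher number from compound 2 to compound 4 (0.53 log units; beyond the scatter). Of the three groups added, 6-aminopyridin-3-yl stays closest to the hydrogen of compound 1, with a 2.2-fold lower number from compound 1 to compound 4 (0.35 log units; beyond the scatter). Nothing available accounts for the gap between 6-aminopyridin-3-yl and 1H-benzimidazol-5-yl.

Going by these compounds, what the amine contributes remains open: plain pyridin-3-yl or a methoxypyridine at this carbon would separate the amine from the ring.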